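Loss of a saturated-ring methyl: forecasting compound 4

This account rests on a few compounds, and the source may have more. Where it says the series, first, only, none or still open, it means among the compounds named here.

Measured so far:
Compound 1, `C[C@@H]1Cc2cc(C(N)=O)cnc2N1`, 38 nM
Compound 2, `NC(=O)c1cnc2c(c1)CCN2`, 142 nM
Compound 3, `Cc1c(C(N)=O)cnc2c1C[C@@H](C)N2`, 12 nM

All three were run in an assay on K562 cells for inhibition of Nicotinamide N-methyltransferase (Homo sapiens), read by mass spectrometry, with a stated time of 24 h; a higher number here means a weaker inhibitor, a lower number a stronger inhibitor. Compound 1 gives 38 nM. Compound 2 differs from it by hydrogen in place of methyl on a saturated ring carbon and gives 142 nM, a step of a 3.7-fold higher number from compound 1 to compound 2 (0.57 log units; beyond the scatter). Compound 3 differs from compound 1 by methyl in place of hydrogen on an aromatic carbon, and compound 3 gives 12 nM, the lowest of the three numbers, with a 3.2-fold lower number from compound 1 to compound 3 (0.50 log units; beyond the scatter).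

Compound 4, `Cc1c(C(N)=O)cnc2c1CCN2`, has not yet been measured. It stands to compound 3 as compound 2 stands to compound 1: the change is hydrogen in place of methyl on a saturated ring carbon, the same change at the same place. The two cores differ by methyl in place of hydrogen on an aromatic carbon. Going by the values given here, the only precedent is the single step from compound 1 to compound 2, so the expectation rests on that one step alone; whether the methyl on the aromatic carbon alters its size is unknown. On that basis a step of a 3.8-fold higher number from compound 3 to compound 4 (0.57 log units; beyond the scatter) is expected for compound 4, beside the earlier 3.7-fold higher number from compound 1 to compound 2 (0.57 log units; beyond the scatter). Compound 4 is therefore estimated at 45 nM, with a plausible range of 20 nM to 110 nM.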

Compound 4, half-maximal inhibitory concentration: 23 nM
Compound 4: middle estimate off by 2.0-fold (0.29 log units), on the high side; the range from low to high includes it.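

In this assay, going by these compounds alone, hydrogen in place of methyl on a saturated ring carbon gives a 1.9-fold higher number from compound 3 to compound 4 (0.28 log units; within the scatter), and the gap between this step and its earlier counterpart stays within what two such steps can scatter: the same change on two cores in this assay, a 3.7-fold higher number (0.57 log units; beyond the scatter) from compound 1 to compound 2 and a 1.9-fold higher number (0.28 log units; within the scatter) from compound 3 to compound 4, 1.9-fold (0.29 log units) apart, within the scatter of two such steps The other change in the set, methyl in place of hydrogen on an aromatic carbon, gives a 6.2-fold lower number from compound 2 to compound 4 (0.79 log units; beyond the scatter), and it also carries from one core to the other without a gap beyond the scatter: the same change on two cores in this assay, a 3.2-fold lower number (0.50 log units; beyond the scatter) from compound 1 to compound 3 and a 6.2-fold lower number (0.79 log units; beyond the scatter) from compound 2 to compound 4, 1.9-fold (0.29 log units) apart, within the scatter of two such steps Within these four compounds the two changes therefore behave as roughly independent, but each rests on only two steps on two cores, and this does not show that the steps are equal in size or that the agreement extends to any other core.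

The compounds shown leave open whether an ethyl group or a longer chain on the saturated ring carbon would follow the same course. They also leave open whether a methoxy group or a chlorine atom on the aromatic carbon would carry between the cores as the methyl does.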